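A few compounds are considered here, and "the series" means these few. Any claim that something is new, unique, unknown or untested is made for them only; others in the source may bear on it.

The compounds here share one core, a sulfonamide-bearing aromatic system carrying a methyl-substituted benzamide, joined to a piperidine whose ring nitrogen carries a carbonyl group; only the group on that carbonyl carbon changes. Compound 1 `Cc1ccccc1C(=O)Nc1ccc(S(=O)(=O)NC2CCN(C(=O)CO)CC2)c2ccccc12` carries a hydroxymethyl there and in an assay on L1.2 cells for binding affinity to C-C chemokine receptor type 8 (Homo sapiens) (on this read-out higher numbers stand for weaker inhibition and lower numbers for stronger inhibition), compound 1 gives 5.4 nM. Compound 2 `Cc1ccccc1C(=O)Nc1ccc(S(=O)(=O)NC2CCN(C(=O)CCCCN)CC2)c2ccccc12` carries a 4-aminobutyl and gives 199 nM. Compound 3 `CNC(=O)N1CCC(NS(=O)(=O)c2ccc(NC(=O)c3ccccc3C)c3ccccc23)CC1` carries a methylamino and gives 0.7 nM, the lowest of the three numbers: a 7.7-fold lower number from compound 1 to compound 3 (0.89 log units; beyond the scatter), and a 280-fold lower number from compound 2 to compound 3 (2.45 log units; beyond the scatter).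

Compound 4 `Cc1ccccc1C(=O)Nc1ccc(S(=O)(=O)NC2CCN(C(=O)N3CCCC3)CC2)c2ccccc12` keeps everything of compound 3 except one change: pyrrolidin-1-yl in place of methylamino on a carbonyl carbon. Among the measured compounds shown here, no measured pair shows this exact exchange. For the measured compounds named here, the steps that bear on it are those at the same carbonyl carbon, a 37-fold higher number from compound 1 to compound 2 (1.57 log units; beyond the scatter) and a 7.7-fold lower number from compound 1 to compound 3 (0.89 log units; beyond the scatter), which show that what sits on this carbon moves the number strongly in both directions. Going by the values given here, the new group removes the single hydrogen-bond donor that compound 3 has at this position and brings in a ring, so a modest rise in this assay is expected rather than none: a 4.3-fold higher number from compound 3 to compound 4 (0.63 log units; beyond the scatter). Compound 4 is therefore estimated at 3 nM, with a range from 0.7 nM to 15 nM.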

Compound 4, inhibition constant: 1.1 nM
Beside the measured number, compound 4's estimate is 2.7-fold (0.44 log units) above it; low and high end bracket the measured number.
By their numbers in this assay, from the lowest: compounds 3 and 4 (each within the scatter of the next); then compound 1; then compound 2.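

In this assay, the exchange of methylamino for pyrrolidin-1-yl on this carbonyl carbon leaves the number within the scatter (a 1.6-fold higher number from compound 3 to compound 4 (0.20 log units; within the scatter)), so at this position neither the hydrogen-bond donor of methylamino nor the absence of a ring is needed for a number in this low range. Compound 4 also stands well clear of the compound with the 4-aminobutyl (a 180-fold lower number from compound 2 to compound 4 (2.26 log units; beyond the scatter)) and of the one with the hydroxymethyl (a 4.9-fold lower number from compound 1 to compound 4 (0.69 log units; beyond the scatter)), so among these four compounds, the two with a nitrogen bound directly to the carbonyl carbon give the lowest numbers, with no compound going against this. None of the data shown explain why the numbers fall this way.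

Going by these compounds, it remains open whether larger or differently built groups on the same carbon, such as dimethylamino, piperidin-1-yl or morpholin-4-yl, would stay in this range. On these data alone, it is also open whether the high number of compound 2 belongs to its terminal amine or to its chain, which a plain pentyl group or a 4-hydroxybutyl group in the same place could help to separate.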